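Aromatic Ring in Place of Cyclohexyl on the Ring Nitrogen

The source may hold more compounds than are shown below. What is called first, only, known or untested is meant among the compounds shown, and "the series" means these compounds.

Compound 1, `O=C(CN1CCN(C2CCCCC2)CC1)Nc1nc2c(s1)CCCC2`: > 1000 nM
Compound 2, `O=C(CN1CCN(c2ccc(F)cc2)CC1)Nc1nc2c(o1)CCCC2`: 180 nM
Compound 3, `O=C(CN1CCN(c2ccc(F)cc2)CC1)Nc1nc2ccccc2s1`: 490 nM

All three compounds were tested in an assay on isolated protein for inhibition of long-chain fatty acid transport protein 1 (Homo sapiens), read by scintillation counting, with a stated time of 20 min; a lower number here means a stronger inhibitor, a higher number a weaker inhibitor. Compound 1 gives > 1000 nM, and this is a limit of the assay rather than a number, so compound 1 sits at the limit of > 1000 nM in this assay, at which 1 of the 3 values shown sits. Compound 2, which carries an aromatic ring on the amine nitrogen in a ring and a different core, gives 180 nM. Compound 3, with the same aromatic ring but a third core, gives 490 nM. No two of these compounds differ in one place only, so no single step among them can be read off.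

Compound 4, `O=C(CN1CCN(c2ccccn2)CC1)Nc1nc2c(s1)CCCC2`, keeps the core of compound 1 and changes only the group on the ring nitrogen: pyridin-2-yl in place of cyclohexyl on an amine nitrogen in a ring. Among the measured compounds shown here, no measured step of this kind exists among the three compounds. The expectation is nonetheless a move toward stronger inhibition, since compound 2, bearing an aromatic ring on the amine nitrogen in a ring, gives 180 nM and compound 3, with the same aromatic ring, gives 490 nM. Compound 1, by contrast, sits only at a limit of the assay. The expected step is an at least 2.2-fold lower number from compound 1 to compound 4 (0.34 log units; beyond the scatter). Compound 4 is therefore estimated at 450 nM, with a range from 120 nM to 2000 nM.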

Compound 4, half-maximal inhibitory concentration: 200 nM
Compound 4: middle estimate off by 2.3-fold (0.35 log units), on the high side; measured number inside the range.
By their numbers in this assay, from the lowest: compounds 2 and 4 (each within the scatter of the next); then compound 3. At a limit, above all of these: compound 1.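

With the core held fixed, pyridin-2-yl in place of cyclohexyl on an amine nitrogen in a ring gives an at least 5.0-fold lower number from compound 1 to compound 4 (0.69 log units; beyond the scatter) in this assay. This is the first change among the compounds shown that can be read at this position on its own, as the earlier aromatic compounds differed from the cyclohexyl compound in their core as well, and it ties the gain to the exchange of a non-aromatic carbon ring for an aromatic ring with one hetero atom. The step gives only a lower bound on the effect of the change, and its full size cannot be read, because compound 1 stands at a limit rather than at a number: the limit of > 1000 nM in this assay, at which 1 of the 4 values shown sits.

As far as these compounds go, it remains open whether phenyl or 4-fluorophenyl on this same core would match pyridin-2-yl, which would separate the contribution of the aromatic ring from that of its ring nitrogen. Also open, from the compounds shown here alone, is how pyridin-3-yl, pyridin-4-yl or benzyl would fare on this ring nitrogen, and so how narrowly the position is tied to pyridin-2-yl.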